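The source may report more compounds than this note shows. Statements on the series, on what has been measured and on what is new or still open speak of the compounds shown alone.

Measured compounds:
compound 1 `Cc1ccc(-c2cc(N3CCC(CNS(N)(=O)=O)CC3)ncn2)cc1` — 30600 nM
compound 2 `COC(=O)c1ccc(-c2cc(N3CCC(CNS(N)(=O)=O)CC3)ncn2)cc1` — 17700 nM

Compound 1 gives the highest of the two numbers recorded in a functional assay on MCF7 cells (Homo sapiens) for antiproliferative activity, read by sulforhodamine B assay, with a stated time of 48 h; on this read-out higher numbers stand for weaker inhibition of growth and lower numbers for stronger inhibition of growth. Within the data shown here, its nearest neighbour is compound 2, and the step of a 1.7-fold lower number from compound 1 to compound 2 (0.24 log units; within the scatter) is the only measured step in this set. Compound 3 `NS(=O)(=O)NCC1CCN(c2cc(-c3cccc(Cl)c3)ncn2)CC1` differs from compound 1 in a single place: 3-chlorophenyl in place of 4-methylphenyl on an aromatic carbon. Among the measured compounds shown here, no measured step touches this exact change; the one step recorded, from compound 1 to compound 2, concerns a different replacement on the same ring and stays within the scatter, so the series so far shows no movement beyond it. On that basis the account expects for compound 3 a step of a 1.2-fold lower number from compound 1 to compound 3 (0.09 log units; within the scatter) in this assay, that is, a number not clearly separated from compound 1. The estimate for compound 3 in this assay is 25000 nM, with a range from 8000 nM to 80000 nM.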

Compound 3, concentration for 50% growth inhibition: 47100 nM
Compound 3: middle estimate off by 1.9-fold (0.28 log units), on the low side; the range from low to high includes it.
By their numbers in this assay, from the lowest: compounds 2, 1 and 3 (each within the scatter of the next, the first and the last beyond it).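

In this assay, 3-chlorophenyl in place of 4-methylphenyl gives a second change at this aromatic carbon that stays within the scatter (a 1.5-fold higher number from compound 1 to compound 3 (0.19 log units; within the scatter)). Compound 1 and compound 3 carry aryl groups of equal heavy-atom count, with no hydrogen-bond donors or acceptors on either, so this change brings no clear separation from compound 1. The step alters both the substituent and its place on the phenyl ring at once, so it cannot divide the two, and nothing measured bears on the reason for the step.

The compounds shown leave open whether an amine or a carboxylic acid on this phenyl ring would move the number beyond the scatter. They also leave open what a longer chain would do in place of the phenyl ring itself.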